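The compounds below may be only part of what the source reports. "The series", "measured", "known", "first", "only" and "open" are said of these compounds alone.

Of the compounds shown here, three have a number so far in a functional assay on the whole organism (heart left ventricle) with Canis familiaris (Canis lupus familiaris) as the target; a higher number here means that more compound is needed for the effect, a lower number that less compound is needed. Compound 1 (`COc1cc(C(N)=O)ccc1-c1nc2cc[nH]cc-2n1`) gives 0.01 mg/kg, compound 3 (`COc1cc(C(N)=O)ccc1-c1cn2ccncc2n1`) gives 0.02 mg/kg, and compound 2 (`COc1cc([S+](C)[O-])ccc1-c1cn2ccncc2n1`) gives 0.75 mg/kg. Compound 3 therefore stands at the low end of these numbers, within the usual scatter of compound 1 and far from compound 2.

Compound 4 (`COc1cc(C(N)=O)ccc1-c1cn2ccnc(OC)c2n1`) is compound 3 with a single change: methoxy in place of hydrogen on an aromatic carbon. A methoxy takes the place of hydrogen on an aromatic carbon, next to the ring nitrogen, in a six-membered aromatic ring that is part of a fused or bridged system of two rings.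

Among the measured compounds shown here, only one measured step links compounds differing in one place, and it is large: a 38-fold lower number from compound 2 to compound 3 (1.57 log units; beyond the scatter). That step swaps a different group at a different place, so it shows that one change can move this assay strongly, but it does not give the size of this new step. For the measured compounds named here, no measured compound carries a group at the new place, so the data offer no direct guide.

With so little evidence, the expectation stays close to compound 3, at 0.02 mg/kg, with a slight lean towards a higher number and a wide range. The expected step is a 1.5-fold higher number from compound 3 to compound 4 (0.18 log units; within the scatter), which would not go beyond the scatter. The estimated value for compound 4 is 0.03 mg/kg, with an expected range from 0.008 mg/kg to 0.1 mg/kg.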

Compound 4, dose for half-maximal effect: 0.06 mg/kg
Compound 4: the middle estimate sits 2.0-fold (0.30 log units) below what was measured; the range from low to high includes it.
By their numbers in this assay, from the lowest: compounds 1 and 3 (each within the scatter of the next); then compound 4; then compound 2.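

In this assay, among the compounds shown here, a 3.0-fold higher number from compound 3 to compound 4 (0.48 log units; beyond the scatter) is the first measured change at this place, so a group on this aromatic carbon next to the ring nitrogen does register in the assay. The change is only one methoxy in place of hydrogen, yet it carries the number beyond the usual scatter, and in the direction of more compound being needed for the effect. Nothing available here, such as a separate measurement of a property of these compounds, bears on why the number moves this way.

With methoxy as the only group shown at this place, one step cannot say whether the rise goes with the oxygen atom, with the methyl part, or with any group at all replacing hydrogen here; a methyl, a chlorine, an amine or an ethoxy at the same carbon would begin to separate these readings. As far as these compounds go, it also remains open whether a methoxy would shift the number by a similar amount on the core of compound 1.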